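A few compounds are considered here, and "the series" means these few. Any claim that something is new, unique, unknown or untested is made for them only; others in the source may bear on it.

Compound 1, with the structure `CC1=NN(c2ccc(C)cc2)C(=O)C12C=CC(=O)C=C2c1ccc(C)cc1`, gives 37000 nM in a functional assay on A549 cells (Homo sapiens) for antiproliferative activity, read by CCK-8 assay, with a stated time of 72 h; a lower number here means a stronger inhibitor, a higher number a weaker inhibitor. Compound 2, with the structure `CC1=NN(c2ccc(Cl)cc2)C(=O)C12C=CC(=O)C=C2c1ccccc1`, returns no number in this assay but only a limit of > 100000 nM, so compound 2 stands at the weak end of what this measurement can report, and that limit, (the limit of > 100000 nM in this assay, at which 1 of the 2 values shown sits), is all that is known about it. Compound 3, with the structure `CC1=NN(c2ccc(Cl)cc2)C(=O)C12C=CC(=O)C=C2c1ccc(C)cc1`, differs from compound 2 by a single change: methyl in place of hydrogen on an aromatic carbon. Compound 1, at 37000 nM, carries the same methyl on its phenyl ring and still sits far toward the weak end, so no large gain is expected from this step, and the difference may well stay within the usual scatter. The step from compound 2 to compound 3 is expected to be an at least 1.6-fold lower number from compound 2 to compound 3 (0.22 log units; that floor lies within the scatter). Compound 3 is therefore expected to give about 60000 nM in this assay, within a likely range from 20000 nM to 150000 nM.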

Compound 3, half-maximal inhibitory concentration: 33400 nM
The estimate for compound 3 lay 1.8-fold (0.25 log units) above the measured number; the range from low to high includes it.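

Putting methyl on the aromatic carbon para to a large group gives, in this assay, an at least 2.9-fold lower number from compound 2 to compound 3 (0.47 log units; beyond the scatter), so the change from phenyl to 4-methylphenyl makes a real difference here. That step is only a floor and the true gap could be larger, because compound 2 is known only through a limit: the limit of > 100000 nM in this assay, at which 1 of the 3 values shown sits. Compound 1 and compound 3 both carry 4-methylphenyl, and with a 1.1-fold lower number from compound 1 to compound 3 (0.04 log units; within the scatter), chloro in place of methyl on the other aromatic ring cannot be told apart from no change.

The compounds shown do not tell whether methyl itself matters at this position, or whether a larger group such as ethyl, or a methoxy or an amine, would do as well or better. They also leave open whether any change here could lift this series far from the weak end of the assay.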